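Swapping the Halogenated Ring on an Inactive Core

This account rests on a few compounds, and the source may have more. Where it says the series, first, only, none or still open, it means among the compounds named here.

Of the compounds shown here, three have been tested in an assay for inhibition of protein disulfide-isomerase (Homo sapiens), with a stated time of 1 h; a higher number here means a weaker inhibitor, a lower number a stronger inhibitor. Compound 1 `Oc1cc2c(cc1C(c1ccc(F)cc1)N1CCCCC1)OCCO2` gives 670 nM, and compound 3 `Oc1ccc2[nH]ncc2c1C(c1ccc(-c2cncnc2)cc1)N1CCCCC1` gives 830 nM. Compound 2 `Cc1ccnc(NC(c2ccc3cccnc3c2O)c2c(F)cccc2Cl)c1`, built on a different core, returns no number but only a limit of the assay: > 40000 nM. Its value sits at the limit of > 40000 nM in this assay, at which 1 of the 3 values shown sits. Compound 4 `Cc1ccnc(NC(c2ccccc2C)c2ccc3cccnc3c2O)c1` keeps the core of compound 2 and differs in a single place: 2-methylphenyl in place of 2-chloro-6-fluorophenyl on a saturated chain carbon bound to an aromatic carbon and a nitrogen on an aromatic ring. Within the data shown here, no pair of measured compounds differs in just one place, so there is no measured step to lean on; the only guide is that compound 2 shows no measurable inhibition. From this, the expected step is a number no higher from compound 2 to compound 4 (the limit leaves the size open), with a fair chance that only a limit is reported again. The estimate for compound 4 is 40000 nM, ranging from 10000 nM to 200000 nM.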

Compound 4, half-maximal inhibitory concentration: > 40000 nM
Compound 4 was reported as a limit (the forecaster's own chance of this, stated with the estimate: 65%); the middle value lies on the limit itself.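

Compound 2 and compound 4 both return only a limit, so the step between them cannot be read: the limit of > 40000 nM in this assay, at which 2 of the 4 values shown sit.

The compounds shown leave open whether any other group in that place on the shared core would give a measurable value.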